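This account rests on a few compounds, and the source may have more. Where it says the series, first, only, none or still open, it means among the compounds named here.

Measured so far in a functional assay on MCF7 cells (Homo sapiens) for antiproliferative activity, with a stated time of 48 h; a lower number here means a stronger inhibitor, a higher number a weaker inhibitor:

compound 1, `CC(C)(C)c1ccc(CNC(=O)NC(=O)CCl)cc1`: 2800 nM
compound 2, `O=C(CCl)Nc1ccc(I)cc1`: 6200 nM
compound 3, `CC(C)(C)c1ccc(NC(=O)CCl)cc1`: 5400 nM

Compound 2 carries the highest of the three numbers. Its nearest neighbour is compound 3, and the step of a 1.1-fold lower number from compound 2 to compound 3 (0.06 log units; within the scatter) stays within the scatter, so no order between the two can be read. Compound 1 lies furthest away, and its value against that of compound 2 is a gap beyond the scatter.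

The untested compound 4, `O=C(CCCCl)Nc1ccc(I)cc1`, differs from compound 2 in a single place: 2-chloroethyl in place of chloro on a saturated chain carbon bound to a carbonyl carbon. Among the measured compounds shown here, the one measured step, from compound 2 to compound 3, concerns only a substituent on the aromatic ring and says nothing about the chain at the carbonyl. For the measured compounds named here, no measured pair therefore bears on this change, and the expectation in this assay must rest on compound 2 alone, with a wide allowance in either direction.

On that basis compound 4 is expected to give 8000 nM, somewhere between 2500 nM and 25000 nM, which means an estimated step of a 1.3-fold higher number from compound 2 to compound 4 (0.11 log units; within the scatter).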

Compound 4, half-maximal inhibitory concentration: > 100000 nM
Compound 4 ended at the assay's limit; the forecaster's own chance of this, stated with the estimate: 10%; at least 12-fold (1.09 log units) between middle value and limit.
By their numbers in this assay, from the lowest: compounds 1, 3 and 2 (each within the scatter of the next, the first and the last beyond it). At a limit, above all of these: compound 4.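

In this assay compound 4 gives > 100000 nM, which is a limit of the assay and not a number: the limit of > 100000 nM in this assay, at which 1 of the 4 values shown sits. Among the compounds shown here, the chain at the carbonyl carbon thus proves to be a sensitive place, as 3-chloropropyl in place of chloromethyl gives an at least 16-fold higher number from compound 2 to compound 4 (1.20 log units; beyond the scatter), whereas the only earlier step, a 1.1-fold lower number from compound 2 to compound 3 (0.06 log units; within the scatter), concerned a substituent on the aromatic ring. Among these compounds, the one change at the chain therefore counts for far more than the one change on the ring.

The compounds shown leave open whether a chloroethyl, bromomethyl or plain methyl group at this place would keep the activity of compound 2. They also leave open whether 3-chloropropyl has the same outcome when tert-butyl stands on the aromatic ring, as in compound 3.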